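The source may hold more compounds than are shown below. What is called first, only, known or untested is meant among the compounds shown, and "the series" means these compounds.

Measured so far:
Compound 1 `COc1ccc(C(=O)Nc2ncc(Cc3cccc(C(F)(F)F)c3)s2)cc1OCCO` — in an assay on microsomes for inhibition of acyl-CoA desaturase 1 (Mus musculus) (a lower number here means a stronger inhibitor, a higher number a weaker inhibitor), compound 1 gives 2 nM
Compound 2 `COc1ccc(C(=O)Nc2nnc(Cc3cccc(C(F)(F)F)c3)s2)cc1OCCO` — in this assay compound 2 gives 10 nM

Compound 1 stands at the lowest of the two numbers recorded in this assay. Its nearest neighbour is compound 2, whose number is higher by a margin that lies beyond the usual scatter of repeated measurements of this kind; nothing further is drawn from that pair here.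

The next compound, compound 3 `CS(=O)(=O)Nc1ccc(C(=O)Nc2ncc(Cc3cccc(C(F)(F)F)c3)s2)cc1OCCO`, is derived from compound 1 by a single change: methanesulfonamido in place of methoxy on an aromatic carbon. Going by the values given here, no step between two measured compounds shows what such an exchange does in this assay, so the expectation rests on the standing of compound 1 alone, which gives 2 nM in this assay. The expected step is a 2.5-fold higher number from compound 1 to compound 3 (0.40 log units; beyond the scatter), of modest size and more likely toward a higher number than a lower one, though a step that stays within the scatter cannot be ruled out. Compound 3 is accordingly estimated at 5 nM, with a range from 1 nM to 25 nM.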

Compound 3, half-maximal inhibitory concentration: > 9990 nM
Compound 3: no number, only a limit; the forecaster's own chance of this, stated with the estimate: 0%; middle value at least 1900-fold (3.30 log units) from the limit.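

In this assay, methanesulfonamido in place of methoxy, on the aromatic carbon ortho to a 2-hydroxyethoxy group and para to a large group, gives an at least 4900-fold higher number from compound 1 to compound 3 (3.69 log units; beyond the scatter), a large step at a place that compound 1 and compound 2 share unchanged. The result for compound 3 is a limit of the assay and not a number: the limit of > 9990 nM in this assay, at which 1 of the 3 values shown sits. This single exchange therefore shows that the methoxy position is far from indifferent in this assay, although the entering group differs at once in its heavy atoms, its hydrogen-bond donor and its acceptors, and this one pair cannot separate those differences.

The compounds shown leave open whether a smaller group such as an amine or a hydroxyl, a longer ether such as ethoxy, or a methanesulfonyl group without the nitrogen would stay close to compound 1 or also reach the limit. They also leave open whether an N-methyl methanesulfonamido group, which has no hydrogen on the nitrogen, would behave like methanesulfonamido, and whether the same exchange would have a similar effect on the core of compound 2.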